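The source may report more compounds than this note shows. Statements on the series, on what has been measured and on what is new or still open speak of the compounds shown alone.

Measured so far in a functional assay on the whole organism (strain Swiss) with Mus musculus as the target, in the maximal electroshock model, with a stated time of 0.25 h, at a dose of 100 mg/kg by the intraperitoneal route; a higher number here means a stronger effect of the compound at the dose given, a lower number a weaker effect:
compound 1, `CCC(C(=O)N1CCN(c2cccc(C)c2)CC1)N1C(=O)CCC1=O` — 50%
compound 2, `CCC(C(=O)N1CCN(c2cccc(Cl)c2)CC1)N1C(=O)CCC1=O` — 50%
compound 3, `Cc1cccc(N2CCN(C(=O)C(C)N3C(=O)CCC3=O)CC2)c1` — 0%

Compound 4, `CC(C(=O)N1CCN(c2cccc(Cl)c2)CC1)N1C(=O)CCC1=O`, is not yet measured. It differs from compound 3 by chloro in place of methyl on an aromatic carbon. The same change is made from compound 1 to compound 2, where it gave no change at the digits printed from compound 1 to compound 2 (within the scatter). The two cores differ by hydrogen in place of methyl on a saturated chain carbon, two bonds along the chain from an amide-type nitrogen in a ring and a carbonyl carbon, a change which on its own gave a number 50 percentage points lower from compound 1 to compound 3 (beyond the scatter). The place of the aryl change reads the same word for word in both pairs, so it is taken as the same change on two cores. In this assay compound 3 stands lowest of the three, with compound 1 and compound 2 both well above it. Since the aryl exchange left compound 1 and compound 2 at the same level, the expected step to compound 4 is small, estimated as a number 5 percentage points higher from compound 3 to compound 4 (within the scatter), resting on the step from compound 1 to compound 2 being within the scatter. Compound 4 is therefore expected to give about 5% in this assay, estimated between 0% and 25%.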

Compound 4, a percentage reported as activity, at one dose (the size of the read-out at that dose, not a potency): 50%
Compound 4: middle estimate off by 45 percentage points, on the low side; measured number outside the range, above it.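

In this assay, chloro in place of methyl on the aromatic ring gives no change at the digits printed from compound 1 to compound 2 (within the scatter) on one core but a number 50 percentage points higher from compound 3 to compound 4 (beyond the scatter) on the other, so this exchange does not carry from one core to the other in this series: the same change on two cores in this assay, no change at the digits printed (within the scatter) from compound 1 to compound 2 and a number 50 percentage points higher (beyond the scatter) from compound 3 to compound 4, 50 percentage points apart, beyond the scatter of two such steps

Read the other way, hydrogen in place of methyl on the saturated chain carbon gives a number 50 percentage points lower from compound 1 to compound 3 (beyond the scatter) but no change at the digits printed from compound 2 to compound 4 (within the scatter), so the effect of that change depends on the aryl group present: the same change on two cores in this assay, a number 50 percentage points lower (beyond the scatter) from compound 1 to compound 3 and no change at the digits printed (within the scatter) from compound 2 to compound 4, 50 percentage points apart, beyond the scatter of two such steps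

Among the compounds shown here, this shows that the two changes are not independent across these compounds, but the whole gap rests on the single low value of compound 3, 0%, and a read-out at one dose shows neither potency nor the reason for the difference.

Open, going by these compounds, is whether the low value is peculiar to the 3-methylphenyl group on that core or would also appear with 3-trifluoromethylphenyl or plain phenyl. Also open, on these data alone, is whether a longer chain on the saturated carbon would stay at the level of compound 1.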